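Removing one methoxy from compound 2

This account rests on a few compounds, and the source may have more. Where it says the series, first, only, none or still open, it means among the compounds named here.

Values measured in a functional assay on A549 cells (Homo sapiens) for cytotoxicity, read by WST assay, with a stated time of 24 h; on this read-out higher numbers stand for weaker inhibition and lower numbers for stronger inhibition:
- Compound 1 `COc1ccc2[nH]cc(/C=C(\C#N)C(=O)c3c[nH]c4ccccc34)c2c1`: 6600 nM
- Compound 2 `COc1ccc2c(/C=C(\C#N)C(=O)c3c[nH]c4cc(OC)ccc34)c[nH]c2c1`: 1900 nM
- Compound 3 `N#C/C(=C\c1c[nH]c2ccc(Br)cc12)C(=O)c1c[nH]c2ccc(Br)cc12`: > 50000 nM (a limit of the assay, not a number)

Only compound 1 and compound 2 give actual numbers in this assay. Of these two, compound 2 has the lower number at 1900 nM, and the higher number of compound 1 lies beyond the scatter of repeated measurements. Compound 3 reaches only a limit, > 50000 nM.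

The next compound to be tested is compound 4 `COc1ccc2c(/C=C(\C#N)C(=O)c3c[nH]c4ccccc34)c[nH]c2c1`, which keeps the shared core of compound 2 but loses one of its methoxy groups. The change is hydrogen in place of methoxy on an aromatic carbon.

Within the data shown here, no measured pair isolates this change. The closest guide is compound 1 at 6600 nM, which also has methoxy on only one half of the molecule, though at a different place. On that basis, weaker inhibition is expected. The estimated change is a 2.1-fold higher number from compound 2 to compound 4 (0.32 log units; beyond the scatter), a modest step near the edge of the scatter. For compound 4 the estimated value is 4000 nM. The expected range runs from 1500 nM to 12000 nM.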

Compound 4, half-maximal inhibitory concentration: 9600 nM
Beside the measured number, compound 4's estimate is 2.4-fold (0.38 log units) below it; measured number inside the range.
By their numbers in this assay, from the lowest: compound 2; then compounds 1 and 4 (each within the scatter of the next). At a limit, above all of these: compound 3.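

In this assay, among these compounds, this is the first pair that differs in one place, and it gives a 5.1-fold higher number from compound 2 to compound 4 (0.70 log units; beyond the scatter), a step beyond the scatter. The methoxy on this aromatic carbon is therefore the first single group in the series shown to make a measurable difference, with stronger inhibition when it is present than when hydrogen takes its place. Neither compound of the pair sits at the limit of the assay, so the step is read between two actual numbers, and the only limit among the compounds shown is this one: the limit of > 50000 nM in this assay, at which 1 of the 4 values shown sits.

Compound 1 and compound 4 each carry a single methoxy and lie within the scatter of each other, so these two compounds give no sign that the place of that one methoxy matters, but they cannot show how far this holds across the series. The compounds shown leave open how a hydroxyl, an amine or a longer ethoxy chain on this aromatic carbon would compare with methoxy, and whether a compound with hydrogen in place of both methoxy groups would read any differently from compound 4.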